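This account rests on a few compounds, and the source may have more. Where it says the series, first, only, none or still open, it means among the compounds named here.

In a functional assay on KARPAS-299 cells (Homo sapiens) for inhibition, read by CellTiter-Glo, with a stated time of 96 h (on this read-out higher numbers stand for weaker inhibition and lower numbers for stronger inhibition), three relatives share one core. Compound 1 (`Cc1cc(Nc2ncc(Cl)c(Nc3cn(C)nc3S(=O)(=O)C(C)C)n2)c(OC2CC2)cc1C(=O)C(C)C`) gives "not determined" (no result reported), so it offers no number to compare. Compound 2 (`Cc1cc(Nc2ncc(Cl)c(Nc3cn(C)nc3S(=O)(=O)C(C)C)n2)c(OC2CC2)cc1C1CCCN(C)C1`) gives 3 nM, and compound 3 (`CCNC(=O)c1cc(OC2CC2)c(Nc2ncc(Cl)c(Nc3cn(C)nc3S(=O)(=O)C(C)C)n2)cc1C`) gives 20 nM, the higher of the two numbers and so the weaker inhibition.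

The next structure, compound 4 (`Cc1cc(Nc2ncc(Cl)c(Nc3cn(C)nc3S(=O)(=O)C(C)C)n2)c(OC2CC2)cc1C1COC1`), has oxetan-3-yl in place of ethylcarbamoyl on an aromatic carbon. The group that leaves has no ring, while the group that enters has a four-membered non-aromatic ring.

Within the data shown here, only one measured step bears on this position: a 6.7-fold higher number from compound 2 to compound 3 (0.82 log units; beyond the scatter). That modest step, with 1-methylpiperidin-3-yl giving way to ethylcarbamoyl, lies beyond the scatter and shows that the group at this place can move the number. Among the measured compounds shown here, it cannot show how oxetan-3-yl will behave, since no measured compound carries that group. Compound 3 sits at the weaker end of the two numbers, so a small move toward stronger inhibition seems more likely than a further loss, and a step larger than the measured one is not expected. The expected change is a 2.5-fold lower number from compound 3 to compound 4 (0.40 log units; beyond the scatter). For compound 4 the estimated value is 8 nM, with an expected range from 2.5 nM to 30 nM.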

Compound 4, half-maximal inhibitory concentration: 19 nM
Compound 4: middle estimate off by 2.4-fold (0.38 log units), on the low side, and the stated range covers the measured number.
By their numbers in this assay, from the lowest: compound 2; then compounds 4 and 3 (each within the scatter of the next).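

In this assay, putting oxetan-3-yl in place of ethylcarbamoyl gives a 1.1-fold lower number from compound 3 to compound 4 (0.02 log units; within the scatter), so on this aromatic carbon, ortho to a methyl group, the two groups cannot be told apart. That holds even though the leaving group has no ring and carries a hydrogen-bond donor, while the entering group has a four-membered non-aromatic ring and no donor. Putting oxetan-3-yl in place of 1-methylpiperidin-3-yl gives a 6.3-fold higher number from compound 2 to compound 4 (0.80 log units; beyond the scatter), so among the three compounds with numbers, compound 2 alone stands apart, and nothing measured here gives a cause for either result.

The compounds shown leave open whether the lower number of compound 2 depends on the ring nitrogen of 1-methylpiperidin-3-yl, a question that a cyclohexyl group or a plain piperidin-3-yl group at the same place would address. They also leave open how a carboxylic acid or a longer chain ending in an amine would behave here, and compound 1 adds nothing, since its entry carries no number.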